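A few compounds are considered here, and "the series" means these few. Any claim that something is new, unique, unknown or untested is made for them only; others in the source may bear on it.

Measured so far in a functional assay on the whole organism (strain Wistar) for inhibition, with Rattus norvegicus as the target, with stated times of 30 min and 3 h, at a dose of 20 mg/kg by the oral route; a lower number here means less inhibition, a higher number more inhibition at the dose given (going by the name of the read-out):

compound 1, `Cc1ccc(C(=O)CCc2nnc(-c3ccccc3)o2)cc1`: 49.3%
compound 2, `Cc1ccc(C(=O)CCc2nnc(-c3ccccc3)o2)c(C)c1`: 58%

Two compounds share the core, and the only difference between them is a methyl in place of hydrogen on an aromatic carbon. In this assay compound 2 cannot be set apart from compound 1: the change reads a number 8.7 percentage points higher from compound 1 to compound 2 (within the scatter), and it is within the scatter. For the measured compounds named here, compound 2 therefore stands level with the one other number rather than above it.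

Compound 3, `COc1ccc(-c2nnc(CCC(=O)c3ccc(C)cc3C)o2)cc1`, is the next step from compound 2. The change is methoxy in place of hydrogen on an aromatic carbon. Going by the values given here, no measured pair bears on a methoxy; the one measured step, a number 8.7 percentage points higher from compound 1 to compound 2 (within the scatter), concerns a methyl and was itself within the scatter. With nothing in the two measured compounds that speaks for a shift in either direction, no step beyond the scatter is expected from compound 2 to compound 3, and the expected step is no change at the digits printed from compound 2 to compound 3 (within the scatter). Compound 3 is accordingly estimated at 58% in this assay, within a range from 44% to 72%.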

Compound 3, a percentage reported as inhibition, in the whole organism at one dose (the size of the read-out at that dose, not a potency): 88.9%
Estimate against measurement, compound 3: 30.9 percentage points below, and the stated range ends below it.
By their numbers in this assay, from the lowest: compounds 1 and 2 (each within the scatter of the next); then compound 3.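

In this assay, for the compounds shown here, the change from phenyl to 4-methoxyphenyl reads a number 30.9 percentage points higher from compound 2 to compound 3 (beyond the scatter) and is the first step that stands clear of the scatter. The read-out therefore responds to a substitution on the aromatic carbon para to a large group, and a methoxy with its 2 heavy atoms is accepted there without loss, whereas the methyl step on the other aromatic ring, a number 8.7 percentage points higher from compound 1 to compound 2 (within the scatter), could not be told from noise. No measurement shown here bears on why this step is so large.

Going by these compounds, whether the gain belongs to the methoxy itself stays open, since one group on one carbon cannot show what a hydroxy, an ethoxy, a chlorine or a dimethylamino group would do in the same place. Also open, on these data alone, is whether the methoxy would bring a step of similar size on compound 1, which lacks the added methyl, or at another carbon of the same ring.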